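The compounds below may be only part of what the source reports. "The series", "measured", "known", "first", "only" and "open" are said of these compounds alone.

Compound 1 `COc1ccc(C2=NN(C3=NC(=O)/C(=C4\C(=O)Nc5ccc(Cl)cc54)S3)C(c3ccc(OC)cc3)C2)cc1`: 200 nM
Compound 2 `COc1ccc(C2=NN(C3=NC(=O)/C(=C4\C(=O)Nc5ccccc54)S3)C(c3ccc(Cl)cc3)C2)cc1`: 77500 nM
Compound 3 `COc1ccc(C2=NN(C3=NC(=O)/C(=C4\C(=O)Nc5ccc(Br)cc54)S3)C(c3ccc(Cl)cc3)C2)cc1`: 120 nM

These three compounds share one core and were tested in a functional assay on cells (Cancer cell lines, Homo sapiens) for cytotoxicity, read by sulforhodamine B assay, with a stated time of 48 h; on this read-out lower numbers stand for stronger inhibition of growth and higher numbers for weaker inhibition of growth. Compound 3 sits at the low end of the three numbers: in this assay compound 1 lies within the usual scatter of compound 3, while compound 2 lies far above it, beyond the scatter.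

Compound 4 `COc1ccc(C2=NN(C3=NC(=O)/C(=C4\C(=O)Nc5ccc(Cl)cc54)S3)C(c3ccc(Cl)cc3)C2)cc1` differs from compound 3 in one place: chloro in place of bromo on an aromatic carbon. For the measured compounds named here, only one measured step touches this part of the molecule, and it is a different exchange: a 650-fold lower number from compound 2 to compound 3 (2.81 log units; beyond the scatter). That step shows that a halogen on this fused ring matters greatly when set against hydrogen, but it says nothing about bromo against chloro. Compound 1, which carries chloro at this position together with a different group on the other aromatic ring, gives 200 nM, within the scatter of compound 3. Taken together, these numbers give no reason to expect a step beyond the scatter in this assay in either direction.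

Compound 4 is therefore expected to give about 150 nM in this assay, with a likely range from 60 nM to 400 nM. The expected step from compound 3 to compound 4 is a 1.3-fold higher number from compound 3 to compound 4 (0.10 log units; within the scatter), within the scatter.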

Compound 4, concentration for 50% growth inhibition: 190 nM
Beside the measured number, compound 4's estimate is 1.3-fold (0.10 log units) below it; measured number inside the range.
By their numbers in this assay, from the lowest: compounds 3, 4 and 1 (each within the scatter of the next); then compound 2.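

In this assay, the exchange of bromo for chloro on this aromatic carbon gives a 1.6-fold higher number from compound 3 to compound 4 (0.20 log units; within the scatter), so the two halogens cannot be told apart here, and chloro in place of hydrogen gives a 410-fold lower number from compound 2 to compound 4 (2.61 log units; beyond the scatter), which shows that the large effect first seen with bromo is not unique to bromo. For the compounds shown here, the exchange on a different aromatic ring, with chloro at the halogen position in both compounds, gives a 1.1-fold lower number from compound 1 to compound 4 (0.02 log units; within the scatter), so chloro and methoxy on that ring cannot be told apart in this pair, and the sharp sensitivity to hydrogen versus halogen on the fused ring system has no counterpart in this exchange. No measurement offered here explains why a halogen at this position makes such a difference.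

On these data alone, it remains open whether the effect needs a halogen at all, or whether fluoro, iodo, methoxy, an amine or a carboxylic acid on the same aromatic carbon would also give numbers near those of compound 3 and compound 4. As far as these compounds go, it is also open whether hydrogen on the different aromatic ring, or a longer chain such as ethoxy there, would leave the number where it stands.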